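The source may hold more compounds than are shown below. What is called first, only, known or untested is meant among the compounds shown, and "the series" means these compounds.

Measured compounds in a functional assay on the whole organism (stomach) for inhibition, with Canis familiaris (Canis lupus familiaris) as the target, at a dose of 5 mg/kg by the intravenous route; on this read-out higher numbers stand for a stronger effect at the one dose given and lower numbers for a weaker effect:
compound 1, `CC(=O)c1c(C)nc2c(OCc3ccccc3)cccn12`: 9%
compound 2, `COCc1c(C)nc2c(OCc3ccccc3)cccn12`: 29%
compound 3, `CSCc1c(C)nc2c(OCc3ccccc3)cccn12`: 8%

Compound 3 stands at the low end of the three numbers, but its gap to compound 1 is within the scatter (a number 1 percentage points lower from compound 1 to compound 3 (within the scatter)); only against compound 2 is the gap beyond the scatter (a number 21 percentage points lower from compound 2 to compound 3 (beyond the scatter)). The shared core carries the benzyloxy group throughout, and the three differ only in the group on the aromatic carbon.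

Compound 4, `CCSCc1c(C)nc2c(OCc3ccccc3)cccn12`, is not yet measured. It differs from compound 3 in one place: methyl in place of hydrogen on a saturated chain carbon bound to a sulfur. Among the compounds with values here, no measured step changes the length of that chain; the two steps beyond the scatter, a number 20 percentage points higher from compound 1 to compound 2 (beyond the scatter) and a number 21 percentage points lower from compound 2 to compound 3 (beyond the scatter), swap one group for another on the aromatic carbon or on the chain carbon, and compound 1 against compound 3 shows no step beyond the scatter. Within the data shown here, the change from methylsulfanyl to ethylsulfanyl has no direct precedent here, so the expectation is a step of no size beyond the scatter, a number 2 percentage points higher from compound 3 to compound 4 (within the scatter), in either direction.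

Compound 4 is therefore estimated at 10% in this assay, with a range from 0% to 25%.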

Compound 4, a percentage reported as inhibition, in the whole organism at one dose (the size of the read-out at that dose, not a potency): 0%
Estimate against measurement, compound 4: 10 percentage points above, and the stated range covers the measured number.
By their numbers in this assay, from the lowest: compounds 4, 3 and 1 (each within the scatter of the next); then compound 2.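

In this assay, methyl in place of hydrogen on a saturated chain carbon bound to a sulfur does not separate the pair (a number 8 percentage points lower from compound 3 to compound 4 (within the scatter)), so methylsulfanyl to ethylsulfanyl gives no change that can be read at this one dose. Compound 4 also stays within the scatter of the acetyl compound (a number 9 percentage points lower from compound 1 to compound 4 (within the scatter)), while the gap from the methoxymethyl compound seen with compound 3 holds for the ethylsulfanyl group as well (a number 29 percentage points lower from compound 2 to compound 4 (beyond the scatter)). No evidence on hand bears on this result. Open, as far as these compounds go, is whether ethoxymethyl, the oxygen counterpart of (ethylsulfanyl)methyl, stays with compound 2 or falls with compound 4. Also open, from the compounds shown here alone, is how an amine such as (dimethylamino)methyl or a longer chain such as propylsulfanyl would read on this carbon.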